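Cytotoxicity notes: methoxy to cyano on the aryl hydrazone

A few compounds are considered here, and "the series" means these few. Any claim that something is new, unique, unknown or untested is made for them only; others in the source may bear on it.

Measured so far:
compound 1, `CC(=O)C[C@H]1O[C@@H](On2cc(CN3C(=O)/C(=N\Nc4ccccc4)c4ccccc43)nn2)[C@H](OC(C)=O)[C@@H](OC(C)=O)[C@@H]1OC(C)=O`, 108000 nM
compound 2, `COc1ccc(N/N=C2\C(=O)N(Cc3cn(O[C@@H]4O[C@H](CC(C)=O)[C@@H](OC(C)=O)[C@H](OC(C)=O)[C@H]4OC(C)=O)nn3)c3ccccc32)cc1`, 95300 nM

In an ADME assay on Vero cells (Chlorocebus sabaeus) for cytotoxicity, read by fluorescence and resazurin assay, with a stated time of 3 days (a lower number here means that less compound is tolerated, a higher number that more compound is tolerated), compound 1 gives 108000 nM and compound 2 gives 95300 nM. Compound 2 holds the lowest of the two numbers, but its nearest neighbour is compound 1 and the step of a 1.1-fold lower number from compound 1 to compound 2 (0.05 log units; within the scatter) stays within the scatter, so the two compounds cannot be told apart on this assay.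

Compound 3, `CC(=O)C[C@H]1O[C@@H](On2cc(CN3C(=O)/C(=N\Nc4ccc(C#N)cc4)c4ccccc43)nn2)[C@H](OC(C)=O)[C@@H](OC(C)=O)[C@@H]1OC(C)=O`, is not yet measured. It differs from compound 2 by cyano in place of methoxy on an aromatic carbon: the methoxy leaves and a cyano enters at the same aromatic carbon, para to a large group.

Among the measured compounds shown here, only one measured step bears on this, a 1.1-fold lower number from compound 1 to compound 2 (0.05 log units; within the scatter), which exchanged hydrogen for methoxy at that carbon and moved the number by nothing beyond the scatter. No other change at this position has been measured. Given that both compounds sit near the same value, compound 3 is expected to follow, with a 1.0-fold higher number from compound 2 to compound 3 (0.02 log units; within the scatter) as no step beyond the scatter. Compound 3 is therefore estimated at 100000 nM, in the range 50000 nM to 200000 nM.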

Compound 3, half-maximal cytotoxic concentration: 75400 nM
Compound 3: middle estimate off by 1.3-fold (0.12 log units), on the high side; the measured number falls inside the stated range.
By their numbers in this assay, from the lowest: compounds 3, 2 and 1 (each within the scatter of the next).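

In this assay, among the compounds shown here, the earlier compounds covered only hydrogen and methoxy on this aromatic carbon, para to a large group. Cyano now joins them, giving a 1.3-fold lower number from compound 2 to compound 3 (0.10 log units; within the scatter) and a 1.4-fold lower number from compound 1 to compound 3 (0.16 log units; within the scatter) as well, so neither exchange that brings in cyano can be separated from the scatter. Across hydrogen, methoxy and cyano, this position has therefore shown no step beyond the scatter, which is a wider statement than the single exchange of hydrogen for methoxy could support, and no measurement at hand offers an explanation for this.

Still open, from the compounds shown here alone, is whether any group on this carbon gives a step beyond the scatter, for example an amine, a carboxylic acid or a longer chain such as butoxy, since the three groups compared here are all small or absent. Also open, going by these compounds, is whether the same carbon would read the same way with the rest of the shared core changed, as every comparison so far keeps that core fixed.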